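From 3-bromophenyl to 4-fluorophenyl: a small expected step

The source may hold more compounds than are shown below. What is called first, only, known or untested is meant among the compounds shown, and "the series" means these compounds.

Compound 1 `COc1cc(OC)c(OC)cc1/C=C/COC(=O)/C=C/c1ccccc1C(F)(F)F`: 123 mg/kg
Compound 2 `COc1cc(OC)c(OC)cc1/C=C/COC(=O)/C=C/c1cccc(Br)c1`: 113 mg/kg

In a functional assay on the whole organism (strain Kunming) with Mus musculus as the target, in the formalin test, with a stated time of 0.5 h (on this read-out lower numbers stand for an effect already at smaller amounts and higher numbers for an effect only at larger amounts of compound), compound 2 gives 113 mg/kg. That number lies within the usual scatter of the number for compound 1, so the data do not rank these two compounds.

The next compound to be measured is compound 3 `COc1cc(OC)c(OC)cc1/C=C/COC(=O)/C=C/c1ccc(F)cc1`. It keeps the rest of compound 2 and changes one group: 4-fluorophenyl in place of 3-bromophenyl on a double-bonded chain carbon bound to a double-bonded chain carbon.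

Among the compounds with values here, only one measured step bears on this change, and it was made at the same place on the chain: a 1.1-fold lower number from compound 1 to compound 2 (0.04 log units; within the scatter). There, one substituted phenyl group replaced another, and the number stayed within the scatter. Within the data shown here, this is thin evidence, as it is a single step and no measured compound carries the 4-fluorophenyl group. Among the measured compounds shown here, with only that step to go on, a change beyond the scatter in this assay is not expected in either direction. The expected size of the change is a 1.0-fold higher number from compound 2 to compound 3 (0.01 log units; within the scatter). The estimated value for compound 3 is 115 mg/kg, with an expected range from 60 mg/kg to 220 mg/kg.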

Compound 3, dose for half-maximal effect: 43.4 mg/kg
Beside the measured number, compound 3's estimate is 2.6-fold (0.42 log units) above it, outside the stated range (below it).
By their numbers in this assay, from the lowest: compound 3; then compounds 2 and 1 (each within the scatter of the next).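

The substituted phenyl group on this double-bonded chain carbon does matter in this assay, which compounds 1 and 2 alone could not show: placing 4-fluorophenyl there gives a 2.6-fold lower number from compound 2 to compound 3 (0.42 log units; beyond the scatter), and the same group gives a 2.8-fold lower number from compound 1 to compound 3 (0.45 log units; beyond the scatter). Both steps lie beyond the scatter, whereas 3-bromophenyl and 2-(trifluoromethyl)phenyl cannot be told apart, so compound 3 stands clear of the other two as the compound with the lowest number, though only modestly. Nothing shown here gives any measured information that could account for this difference between the groups.

The step from compound 2 to compound 3 changes both the halogen and its place on the phenyl ring, so the compounds shown cannot say whether the lower number goes with the fluorine or with its place in 4-fluorophenyl; 3-fluorophenyl and 4-bromophenyl would pull these two changes apart. As far as these compounds go, it also remains open how a plain phenyl group would compare, and so whether any halogen is needed at all on this double-bonded chain carbon.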